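The compounds below may be only part of what the source reports. "The series", "measured", "known", "first", "only" and "open" are said of these compounds alone.

Three esters built on one shared core have been measured in a physicochemical assay for solubility, in phosphate buffer, with a stated time of 16 h; a lower number here means a less soluble compound, a higher number a more soluble compound. Compound 1 `CC(=O)OC[C@H]1O[C@@H](n2cnc3c(N)ncnc32)[C@@H](O)[C@@H]1O` gives 6600 ug/mL. Compound 2 `CC(C)(C)CC(=O)OC[C@H]1O[C@@H](n2cnc3c(N)ncnc32)[C@@H](O)[C@@H]1O` gives 7800 ug/mL in this assay, a change of a 1.2-fold higher number from compound 1 to compound 2 (0.07 log units; within the scatter). Compound 3 `CC(C)CC(=O)OC[C@H]1O[C@@H](n2cnc3c(N)ncnc32)[C@@H](O)[C@@H]1O` gives 19800 ug/mL in this assay, the highest number of the three; the steps leading to it are a 3.0-fold higher number from compound 1 to compound 3 (0.48 log units; beyond the scatter) and a 2.5-fold higher number from compound 2 to compound 3 (0.40 log units; beyond the scatter).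

Compound 4 `Nc1ncnc2c1ncn2[C@@H]1O[C@H](COC(=O)c2ccccc2)[C@@H](O)[C@@H]1O` has not yet been measured. It differs from compound 3 in a single place: phenyl in place of isobutyl on a carbonyl carbon. Going by the values given here, none of the measured steps bears directly on this change. Each of them alters only the branching of a saturated chain on the carbon bound to the carbonyl, and none of them exchanges that chain for a ring. The steps seen so far have been modest at most, so a very large swing is not anticipated, yet the change in compound 4 is of a different kind from anything measured, and the estimate must be given a wide range. Because compound 3 gives 19800 ug/mL and the widest measured step is a 3.0-fold higher number from compound 1 to compound 3 (0.48 log units; beyond the scatter), compound 4 is expected to give about 7000 ug/mL in this assay, with a range from 2000 ug/mL to 20000 ug/mL. The implied step, a 2.8-fold lower number from compound 3 to compound 4 (0.45 log units; beyond the scatter), is expected to be a modest move downward.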

Compound 4, solubility: 80 ug/mL
Beside the measured number, compound 4's estimate is 88-fold (1.94 log units) above it, and the stated range ends above it.
By their numbers in this assay, from the lowest: compound 4; then compounds 1 and 2 (each within the scatter of the next); then compound 3.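

On a carbonyl carbon, the saturated chains methyl, isobutyl and neopentyl had kept the numbers in this assay within a narrow band, but phenyl, the first ring at this position, brings a 250-fold lower number from compound 3 to compound 4 (2.39 log units; beyond the scatter) and stands apart from the other two esters as well, with a 98-fold lower number from compound 2 to compound 4 (1.99 log units; beyond the scatter) and an 83-fold lower number from compound 1 to compound 4 (1.92 log units; beyond the scatter) in the same direction. Going by these compounds alone, the three chains therefore differ far less from one another than any of them differs from phenyl, and the earlier steps gave no sign that a single exchange here could move the number so far. Nothing measured in this set accounts for the size of this drop.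

On these data alone, it remains open whether this fall belongs to an aromatic ring in particular or to any ring, a question that a cyclohexyl group on the same carbonyl carbon would help to settle. Also open, as far as these compounds go, is whether a phenyl ring carrying an amine or a carboxylic acid would stay as low as compound 4 or return towards the chain esters.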